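The compounds below may be only part of what the source reports. "The series", "measured", "known", "first", "only" and "open" are said of these compounds alone.

Measured in a functional assay on HCT-116 cells (Homo sapiens) for antiproliferative activity, read by MTT assay, with a stated time of 48 h; a lower number here means a stronger inhibitor, a higher number a weaker inhibitor:
- compound 1 `CCCCC(CCO)n1cnc2c(Cl)nc(F)nc21`: 13500 nM
- compound 2 `CCCCC(CCO)n1cnc2c(Cl)ncnc21`: > 50000 nM (a limit)
- compound 3 `CCCCC(CCO)n1cnc2c(N)ncnc21`: > 50000 nM (a limit)

Compound 2 stands at > 50000 nM, which is a limit and not a number. This is the limit of > 50000 nM in this assay, at which 2 of the 3 values shown sit.

Compound 4 `CCCCCCCCCCCC(CCO)n1cnc2c(Cl)ncnc21` has not yet been measured. It carries heptyl in place of hydrogen on a saturated chain carbon, five bonds along the chain from an aromatic nitrogen.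

Neither measured step touches that chain. The only readable one, an at least 3.7-fold higher number from compound 1 to compound 2 (0.56 log units; beyond the scatter), is a change of hydrogen in place of fluoro on an aromatic carbon. The other, a step that the two limits leave unreadable from compound 2 to compound 3, is a change of amino in place of chloro on an aromatic carbon. The expectation is therefore loose. Compound 1 at 13500 nM shows that a measurable number is possible with this chain-bearing scaffold, so a modest move towards a lower number is expected. Even so, compound 4 may well stay at the limit. The expected step is an at least 2.5-fold lower number from compound 2 to compound 4 (0.39 log units; beyond the scatter). For compound 4 the estimate is 20000 nM, with an expected range from 6000 nM to 50000 nM.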

Compound 4, half-maximal inhibitory concentration: 7590 nM
Beside the measured number, compound 4's estimate is 2.6-fold (0.42 log units) above it, and the stated range covers the measured number.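

In this assay, heptyl in place of hydrogen on a saturated chain carbon, five bonds along the chain from an aromatic nitrogen, gives an at least 6.5-fold lower number from compound 2 to compound 4 (0.81 log units; beyond the scatter). For the compounds shown here, the earlier readable step was a change on an aromatic carbon, so this is the first evidence that the chain position can also move the read-out, and that a measurable number is reachable with the chloro and hydrogen of compound 2 kept in place. Compound 2 stands at > 50000 nM, which is a limit and not a number, and such limits recur in this set: the limit of > 50000 nM in this assay, at which 2 of the 4 values shown sit.

Whether the effect tracks chain length stays open, as heptyl is the only group shown at this position; propyl, decyl or a chain ending in an amine or a carboxylic acid would test this. As far as these compounds go, it is also open whether heptyl would act alike alongside the fluoro of compound 1 or the amino of compound 3.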